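An Alpha-Methyl on the Acetic Acid Arm

The compounds below may be only part of what the source reports. "The series", "measured", "known", "first", "only" and "open" are said of these compounds alone.

In a functional assay on CHO cells for antagonist activity at sphingosine 1-phosphate receptor 2 (Homo sapiens), read by calcium flux (a higher number here means a weaker inhibitor, a lower number a stronger inhibitor), three compounds set the scene. Compound 1 `COc1ccc(Cl)cc1NC(=O)Cc1nn(CC(=O)O)c(=O)c2ccccc12` reaches only a limit of the assay, > 1790 nM, and so supplies no number. Compound 2 `O=C(O)Cc1nn(Cc2cn3cc(OCC4CC4)c(Cl)cc3n2)c2ccccc2c1=O` gives 20 nM, and compound 3 `C[C@H](C(=O)O)n1nc(Cn2cc3cc(OCC4CC4)c(Cl)cc3n2)c2ccccc2c1=O` gives 3.2 nM. Of the two numbers shown, compound 2 stands highest, with compound 3 lying a step below it that goes beyond the usual scatter. For the measured compounds named here, no pair of measured compounds differs in a single place, so the values of compound 2 and compound 3 can only be read side by side.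

Compound 4 `C[C@H](C(=O)O)c1nn(Cc2cn3cc(OCC4CC4)c(Cl)cc3n2)c2ccccc2c1=O` has not yet been measured. It differs from compound 2 by methyl in place of hydrogen on a saturated chain carbon bound to an aromatic carbon and a carbonyl carbon, turning the carboxymethyl into a 1-carboxyethyl. Compound 3 also carries a methyl on its carboxy-bearing carbon and sits at the lower number, but its core is joined differently as well, so that comparison cannot be reduced to this one change. For compound 4 the expected step is a 2.0-fold lower number from compound 2 to compound 4 (0.30 log units; within the scatter), towards a lower number and of a size that may only just exceed the scatter. The estimate for compound 4 is 10 nM, within a range from 3 nM to 40 nM.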

Compound 4, half-maximal inhibitory concentration in the sphingosine 1-phosphate receptor 2 assay: 3.2 nM
Compound 4: middle estimate off by 3.1-fold (0.49 log units), on the high side; low and high end bracket the measured number.
By their numbers in the sphingosine 1-phosphate receptor 2 assay, from the lowest: compounds 3 and 4 (each within the scatter of the next); then compound 2. At a limit, above all of these: compound 1.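

For the compounds shown here, in the sphingosine 1-phosphate receptor 2 assay, methyl in place of hydrogen on a saturated chain carbon bound to an aromatic carbon and a carbonyl carbon gives a 6.3-fold lower number from compound 2 to compound 4 (0.80 log units; beyond the scatter), the first single change in this set whose size can be read, since the earlier compounds offered no pair differing in one place. The step lies beyond the scatter, so this chain carbon is a position where one added methyl is enough to move the number in this assay. In a physicochemical assay for solubility, measured as thermodynamic solubility, at pH 7.4 (a lower number here means a less soluble compound, a higher number a more soluble compound), the same change from carboxymethyl to 1-carboxyethyl gives a 1.0-fold lower number from compound 2 to compound 4 (0.01 log units; within the scatter), with compound 2 at 919 ug/mL and compound 4 at 892 ug/mL, so the step appears in one assay and not in the other.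

As far as these compounds go, whether an ethyl group or a second methyl on this carbon would extend the step, or whether the opposite mirror-image arrangement of the methyl would match it, remains open. None of the measurements shown bears on why the added methyl produces this step.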